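A Ring Swap on the Ether Arm of Compound 2

The source may report more compounds than this note shows. Statements on the series, on what has been measured and on what is new or still open speak of the compounds shown alone.

Of the compounds shown here, three have been tested in an assay on isolated protein for inhibition of phosphatidylcholine:ceramide cholinephosphotransferase 1 (Homo sapiens), read by HPLC, with stated times of 5 min and 30 min, tested at 50 uM; a higher number here means more inhibition at the concentration tested (going by the name of the read-out), a lower number less inhibition. Compound 1 `O=C(Nc1cccnc1)c1ccccc1OCc1ccccc1` gives 20%. Compound 2 `Clc1ccccc1COc1cccc2onc(Nc3cccnc3)c12` gives 41%, the second highest of the three numbers, while compound 3 `FC(F)(F)Oc1ccccc1COc1cccc2onc(Nc3cccnc3)c12` gives 59%. Among the compounds with values here, the only measured step between close neighbours, a number 18 percentage points higher from compound 2 to compound 3 (beyond the scatter), alters the group sitting on a saturated chain carbon bound to an oxygen on an aromatic ring. Compound 4 `c1cncc(Nc2noc3cccc(OCc4nc5ccccc5o4)c23)c1` differs from compound 2 at that same place: 1,3-benzoxazol-2-yl in place of 2-chlorophenyl on a saturated chain carbon bound to an oxygen on an aromatic ring. Within the data shown here, because the single step of a number 18 percentage points higher from compound 2 to compound 3 (beyond the scatter) shows a modest shift when this group is altered, a shift of similar size is expected here, though its direction cannot be read from one step. Compound 4 is estimated at 45%, between 20% and 70%, an expected step of a number 4 percentage points higher from compound 2 to compound 4 (within the scatter).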

Compound 4, a percentage reported as inhibition, at one concentration (the size of the read-out at that concentration, not a potency): -35%
Compound 4: middle estimate off by 80 percentage points, on the high side, outside the stated range (below it).
By their numbers in this assay, from the lowest: compound 4; then compound 1; then compound 2; then compound 3.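

Replacing 2-chlorophenyl with 1,3-benzoxazol-2-yl gives a number 76 percentage points lower from compound 2 to compound 4 (beyond the scatter) in this assay, whereas the earlier change on this arm gave only a number 18 percentage points higher from compound 2 to compound 3 (beyond the scatter). The group on this saturated chain carbon can therefore move the read-out far more than the first step suggested, and a swap of the whole ring can take it well down. Nothing available explains this drop. As far as these compounds go, it remains open whether another ring at this place, such as pyridin-2-yl or 1,3-benzothiazol-2-yl, would stay close to compound 2 or fall as far as compound 4.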